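From a Methyl Ester to a Benzyl Amide

This account rests on a few compounds, and the source may have more. Where it says the series, first, only, none or still open, it means among the compounds named here.

Among the compounds with values here, compound 2 `COC(=O)c1ccc2c(ccn2-c2ccc(NC(=O)c3cccc(C(F)(F)F)c3)cc2)n1` is one of two compounds measured in a functional assay on A375P cells (Homo sapiens) for cytotoxicity, read by MTT assay; a lower number here means a stronger inhibitor, a higher number a weaker inhibitor: compound 2 gives 9500 nM, the higher of the two numbers, while compound 1 `O=C(Nc1ccc(-n2ccc3nc(C(=O)NCc4ccccc4)ccc32)cc1)Nc1ccc(Cl)c(C(F)(F)F)c1` gives 1100 nM, a gap beyond the scatter. Compound 3 `O=C(Nc1ccc(-n2ccc3nc(C(=O)NCc4ccccc4)ccc32)cc1)c1cccc(C(F)(F)F)c1` has not been measured. It differs from compound 2 by benzylamino in place of methoxy on a carbonyl carbon. Within the data shown here, no measured pair isolates this change, so its size in this assay is open; a move toward a lower number is expected, and the estimated step is a 3.8-fold lower number from compound 2 to compound 3 (0.58 log units; beyond the scatter). Compound 3 is expected to give about 2500 nM, within 800 nM to 8000 nM.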

Compound 3, half-maximal inhibitory concentration: 3000 nM
Compound 3: the middle estimate sits 1.2-fold (0.08 log units) below what was measured; measured number inside the range.
By their numbers in this assay, from the lowest: compound 1; then compound 3; then compound 2.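

In this assay, replacing methoxy with benzylamino on the carbonyl carbon now has a measured size, a 3.2-fold lower number from compound 2 to compound 3 (0.50 log units; beyond the scatter) (a modest move toward stronger inhibition). The other end of the molecule matters too: 3-(trifluoromethyl)phenyl in place of (4-chloro-3-(trifluoromethyl)phenyl)amino on a carbonyl carbon gives a 2.7-fold higher number from compound 1 to compound 3 (0.44 log units; beyond the scatter) (a modest move toward weaker inhibition). No supporting data explain either step. Open questions are how a carboxylic acid or a simple amine would compare with benzylamino on that carbonyl, and whether the benzylamino step would be the same size with the other end of compound 1.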